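Alkoxy chain length at the anilide oxygen

A few compounds are considered here, and "the series" means these few. Any claim that something is new, unique, unknown or untested is made for them only; others in the source may bear on it.

Measured so far:
compound 1 `COc1ccc(NC(=O)CCCCCCCSc2nnc(Cc3nn(C)c(=O)c4ccccc34)n2C)cc1`: 3900 nM
compound 2 `CC(C)Oc1ccc(NC(=O)CCCCCCCSc2nnc(Cc3nn(C)c(=O)c4ccccc34)n2C)cc1`: 1100 nM

In an assay on isolated protein (Mus musculus) for inhibition of IL15-IL15 receptor (Homo sapiens), read by resazurin assay, with stated times of 30 min and 2.5 days (on this read-out higher numbers stand for weaker inhibition and lower numbers for stronger inhibition), compound 2 gives the lowest of the two numbers; its nearest neighbour is compound 1, and the step of a 3.5-fold lower number from compound 1 to compound 2 (0.55 log units; beyond the scatter) came with isopropyl in place of methyl on an oxygen on an aromatic ring. Compound 3 `CC(C)COc1ccc(NC(=O)CCCCCCCSc2nnc(Cc3nn(C)c(=O)c4ccccc34)n2C)cc1` carries the change (isobutyl in place of isopropyl on an oxygen on an aromatic ring). For the measured compounds named here, only that one step bears on it, and it was modest, so a further growth of the alkyl group is expected to bring at most a small gain, a 1.4-fold lower number from compound 2 to compound 3 (0.14 log units; within the scatter), in this assay. Compound 3 is expected at 800 nM, within 300 nM to 2500 nM.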

Compound 3, half-maximal inhibitory concentration: 4800 nM
For compound 3 the middle estimate is 6.0-fold (0.78 log units) below the measured one; the whole stated range lies below it.
By their numbers in this assay, from the lowest: compound 2; then compounds 1 and 3 (each within the scatter of the next).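

In this assay the gain with isopropyl does not extend to isobutyl: the step is a 4.4-fold higher number from compound 2 to compound 3 (0.64 log units; beyond the scatter) and it cancels that gain. Set against methyl on the same oxygen, isobutyl gives a 1.2-fold higher number from compound 1 to compound 3 (0.09 log units; within the scatter) and the two cannot be told apart, so potency at this oxygen does not follow alkyl size in a steady trend, with isobutyl going against the earlier gain. Nothing on hand explains this turn. Going by these compounds, whether a straight propyl or a cyclopropylmethyl group on this oxygen would hold the number of compound 2 stays open. An alkoxy chain ending in an amine is equally untested in the compounds shown.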